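Cyano in place of fluoro: note on compound 4

The source may report more compounds than this note shows. Statements on the series, on what has been measured and on what is new or still open speak of the compounds shown alone.

Compound 3 `Cc1nn(C)c(C)c1-c1ccc(-c2nnc(N(C)Cc3ccc4nccn4c3)o2)c(F)c1` stands second highest of the three numbers in a physicochemical assay for lipophilicity, at pH 7.4; on this read-out higher numbers stand for higher lipophilicity and lower numbers for lower lipophilicity; compound 3 gives 3.2. Its nearest neighbour is compound 2 `Cc1noc(C)c1-c1ccc(-c2nnc(N(C)Cc3ccc4nccn4c3)o2)cc1`, which in this assay gives 3.1, the two values lying within the scatter of each other. Compound 1 `Cc1ccccc1-c1ccc(-c2nnc(N(C)Cc3ccc4nccn4c3)o2)cc1` gives 4.7, and the step of a number 1.60 log units lower from compound 1 to compound 2 (beyond the scatter) is the only resolved one in this set. Compound 4 `Cc1nn(C)c(C)c1-c1ccc(-c2nnc(N(C)Cc3ccc4nccn4c3)o2)c(C#N)c1` differs from compound 3 by cyano in place of fluoro on an aromatic carbon, on an aromatic carbon ortho to a large group. Within the data shown here, that measured step concerns another part of the shared core; no measured step bears on the present change, so the expectation rests on the change alone. Compound 4 is expected to give 2.6, between 2.1 and 3.1. The expected step is a number 0.60 log units lower from compound 3 to compound 4 (beyond the scatter).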

Compound 4, distribution coefficient: 2.9
For compound 4 the middle estimate is 0.30 log units below the measured one; measured number inside the range.
By their numbers in this assay, from the lowest: compounds 4, 2 and 3 (each within the scatter of the next); then compound 1.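

In this assay the exchange of cyano in place of fluoro on an aromatic carbon ortho to a large group gives a number 0.30 log units lower from compound 3 to compound 4 (within the scatter) and so leaves no resolved difference between these two groups at this position. Among these compounds, the only earlier resolved step concerns another part of the shared core, so this is the first reading at this place. No supporting data bear on the reason for this result.

As far as these compounds go, whether an amine or a carboxylic acid on this same carbon would separate from fluoro and cyano remains open. Also open, from the compounds shown here alone, is whether the exchange reads alike with a 3,5-dimethyl-1,2-oxazol-4-yl group in place of the 1,3,5-trimethyl-1H-pyrazol-4-yl group.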